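Pyrazolopyridine hydrazinyl ureas: aryl to methyl swap

The compounds below may be only part of what the source reports. "The series", "measured", "known", "first", "only" and "open" are said of these compounds alone.

Measured so far:
- compound 1 `Cn1ncc2c(-c3ccccc3)cc(NNC(=O)Nc3cc(Cl)nc(Cl)c3)nc21`: 76900 nM
- compound 2 `Cn1ncc2c(-c3ccc(F)cc3)cc(NNC(=O)Nc3cc(Cl)cc(Cl)c3)nc21`: 54300 nM
- compound 3 `Cc1nn(C)c2nc(NNC(=O)Nc3cc(Cl)nc(Cl)c3)cc(-c3ccc(F)cc3)c12`: 17400 nM

In a functional assay on SW620/5-FU cells (Homo sapiens) for cytotoxicity, read by MTT assay, with a stated time of 48 h, in the presence of a further agent that is not named here (on this read-out lower numbers stand for an effect already at smaller amounts and higher numbers for an effect only at larger amounts of compound), compound 3 gives 17400 nM, the lowest number of the three; its gap to compound 2 and its gap to compound 1 both lie beyond the scatter, so compound 3 stands as the most potent of the set on this read-out. The other two differ from compound 3 in more than one place, so no single change can be tied to any of these gaps.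

Compound 4 `Cc1cc(NNC(=O)Nc2cc(Cl)nc(Cl)c2)nc2c1c(C)nn2C` is not yet measured. Its difference from compound 3 is methyl in place of 4-fluorophenyl on an aromatic carbon. Every measured compound in the series carries an aryl group at this position, so nothing here shows directly what its loss does. Still, a large group going out and only a methyl coming in is a substantial change, and an expected step from compound 3 to compound 4 of a 2.6-fold higher number from compound 3 to compound 4 (0.41 log units; beyond the scatter) toward a higher number, beyond the scatter, seems the more likely outcome. Compound 4 is thus estimated at 45000 nM, with a range from 12000 nM to 170000 nM.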

Compound 4, half-maximal effective concentration: > 100000 nM
Compound 4 gave a limit, no number; the forecaster's own chance of this, stated with the estimate: 20%; at least 2.2-fold (0.34 log units) between middle value and limit.
By their numbers in this assay, from the lowest: compound 3; then compounds 2 and 1 (each within the scatter of the next). At a limit, above all of these: compound 4.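

In this assay, the first direct read on this aromatic carbon, opposite the ring nitrogen, is an at least 5.7-fold higher number from compound 3 to compound 4 (0.75 log units; beyond the scatter) for methyl in place of 4-fluorophenyl. Compounds 1, 2 and 3 all carry an aryl group here, so only compound 4 shows that this swap costs activity on this read-out, and by a clear margin. The step is a lower bound rather than a measured size, and how much activity remains in compound 4 stays unknown: the limit of > 100000 nM in this assay, at which 1 of the 4 values shown sits.

On these data alone, whether anything other than an aryl group can hold activity at this carbon stays open, for example an ethyl, a cyclohexyl or a morpholine ring. The contribution of the fluorine alone also stays open, as no pair of compounds shown differs by that change only.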